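A few compounds are considered here, and "the series" means these few. Any claim that something is new, unique, unknown or untested is made for them only; others in the source may bear on it.

Three compounds have numbers so far in an ADME assay on BHK-21 cells (Mesocricetus auratus) for cytotoxicity, read by MTT assay, with a stated time of 72 h (a lower number here means that less compound is tolerated, a higher number that more compound is tolerated), for now:

compound 1 `Cc1ccccc1C1CC(c2ccc(OCc3ccccc3)cc2)=NN1c1ccc(S(N)(=O)=O)cc1` gives 20000 nM
compound 2 `Cc1ccc(C2CC(c3ccccc3)=NN2c2ccc(S(N)(=O)=O)cc2)cc1` gives 7000 nM
compound 3 `NS(=O)(=O)c1ccc(N2N=C(c3ccccc3)CC2c2ccccc2Cl)cc1` gives 13000 nM

Compound 1 stands well up in this small set. Its number is clearly higher than that of compound 2, and it lies within the scatter of the number for compound 3.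

Compound 4 `NS(=O)(=O)c1ccc(N2N=C(c3ccc(OCc4ccccc4)cc3)CC2c2ccc(F)cc2)cc1` has not been measured yet. It differs from compound 1 in one place, with 4-fluorophenyl in place of 2-methylphenyl on a saturated ring carbon. Among the measured compounds shown here, one measured step bears on this change. It also exchanges one substituted phenyl group for another on a saturated ring carbon, putting 2-chlorophenyl in place of 4-methylphenyl, and its size was small (a 1.9-fold higher number from compound 2 to compound 3 (0.27 log units; within the scatter)). For the measured compounds named here, no measured compound carries 4-fluorophenyl, so the expectation rests on that single step and remains uncertain. On this evidence, no change beyond the scatter is expected in this assay in either direction. The estimated shift is slight (a 1.1-fold lower number from compound 1 to compound 4 (0.05 log units; within the scatter)) and has no firm direction. Compound 4 is expected to give about 18000 nM with an estimated range from 8000 nM to 40000 nM once it is measured.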

Compound 4, half-maximal cytotoxic concentration: 60000 nM
The estimate for compound 4 lay 3.3-fold (0.52 log units) below the measured number, outside the stated range (above it).
By their numbers in this assay, from the lowest: compounds 2, 3 and 1 (each within the scatter of the next, the first and the last beyond it); then compound 4.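

In this assay, placing 4-fluorophenyl where compound 1 has 2-methylphenyl gives a clear shift toward more compound being tolerated (a 3.0-fold higher number from compound 1 to compound 4 (0.48 log units; beyond the scatter)). Among the compounds shown here, this shows that a change on this saturated ring carbon can move the number beyond the usual scatter, which the only earlier step at this position did not do (a 1.9-fold higher number from compound 2 to compound 3 (0.27 log units; within the scatter)). The two groups match in everything counted here, each with 7 heavy atoms, one six-membered aromatic ring of carbon only and no hydrogen-bond donors or acceptors, and nothing measured here accounts for the shift.

The step swaps the substituent on the phenyl ring and also moves it to a different ring position, so the compounds shown cannot tell whether the methyl-to-fluorine exchange, the new location or both matter on this core. They also leave open how this position would respond to something quite different from a substituted phenyl group, such as a group carrying an amine or a carboxylic acid, or a longer chain.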